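Compound 3: phenyl in place of ethyl

A few compounds are considered here, and "the series" means these few. Any claim that something is new, unique, unknown or untested is made for them only; others in the source may bear on it.

Measured in an ADME assay on H1-HeLa cells (Homo sapiens) for cytotoxicity, read by MTT assay, with a stated time of 3 days; a lower number here means that less compound is tolerated, a higher number that more compound is tolerated:
- compound 1 `CCOC(=O)c1sc2cc(Oc3ccnc(C(=O)NC)c3)ccc2c1N`: 110 nM
- compound 2 `CCOC(=O)c1sc2cc(Oc3ccnc(C(=O)OC)c3)ccc2c1C`: 24900 nM
- compound 3 `CCOC(=O)c1ccc2ccc(Oc3ccnc(C(=O)NC)c3)cc2c1`: 20800 nM

In this assay compound 3, at 20800 nM, stands within the scatter of compound 2 at 24900 nM. Compound 1, at 110 nM, lies far lower than both.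

Compound 4 `CNC(=O)c1cc(Oc2ccc3ccc(C(=O)Oc4ccccc4)cc3c2)ccn1` departs from compound 3 in one place: phenyl in place of ethyl on an oxygen next to a carbonyl group. Within the data shown here, no two measured compounds differ in only one place, so the data give no direct size for this change, and the expectation remains loose. A modest move toward a lower number is expected, with no step beyond the scatter being equally possible. The estimate is a 1.7-fold lower number from compound 3 to compound 4 (0.24 log units; within the scatter).

For compound 4 the expected value is 12000 nM, with an estimated range of 3000 nM to 40000 nM.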

Compound 4, half-maximal cytotoxic concentration: > 100000 nM
Compound 4 gave a limit, no number (the forecaster's own chance of this, stated with the estimate: 15%); middle value at least 8.3-fold (0.92 log units) away from the limit.
By their numbers in this assay, from the lowest: compound 1; then compounds 3 and 2 (each within the scatter of the next). At a limit, above all of these: compound 4.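

In this assay, this ester position now has its first single-place step: phenyl in place of ethyl on an oxygen next to a carbonyl group gives an at least 4.8-fold higher number from compound 3 to compound 4 (0.68 log units; beyond the scatter). Compound 4 reads > 100000 nM, which is a limit of the assay and not a number. The group on this oxygen therefore matters in this assay, at least on the core shared by compound 3 and compound 4, and the step's size is fixed from one side only: the limit of > 100000 nM in this assay, at which 1 of the 4 values shown sits.

Going by these compounds, whether the same change moves the number the same way on the core of compound 1 remains open. Also open, on these data alone, is how a methyl, a longer chain or a benzyl on this oxygen would read, or a carboxylic acid in place of the ester.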